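Amide Swap: Cyclopentyl Out, Methylpiperazine In

The source may hold more compounds than are shown below. What is called first, only, known or untested is meant among the compounds shown, and "the series" means these compounds.

Three compounds share one core. Compound 1 `O=C(CCSc1nc2cc(Cl)ccc2o1)N1CCC1` was tested in an ADME assay on microsomes from liver (Mus musculus) for metabolic stability, read by LC-MS, using NADPH, with a stated time of 45 min, tested at 0.5 uM (a higher number here means faster removal of the compound, a lower number slower removal), where compound 1 gives 17.9 mL/min/g. Compound 2 `O=C(CCSc1nc2cc(Cl)ccc2o1)NC1CCCC1` is a close relative, yet in this assay compound 2 shows "not determined" (no result reported), so there is no number to place it against compound 1. Compound 3 `CN1CCN(C(=O)CCSc2nc3cc(Cl)ccc3o2)CC1` differs from compound 2 in one place: 4-methylpiperazin-1-yl in place of cyclopentylamino on a carbonyl carbon. Among the measured compounds shown here, no measured step covers a change of this kind, so neither a rise nor a fall beyond the usual scatter can be claimed with confidence. Compound 3 is expected to give about 12 mL/min/g in this assay, within an estimated range from 4 mL/min/g to 40 mL/min/g.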

Compound 3, intrinsic clearance in a liver preparation (reported as CLH), per the amount of preparation that the assay uses: 41.5 mL/min/g
For compound 3 the middle estimate is 3.5-fold (0.54 log units) below the measured one; measured number above the stated range.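

The group on this carbonyl carbon does matter for clearance: in this assay, 4-methylpiperazin-1-yl in place of azetidin-1-yl gives a 2.3-fold higher number from compound 1 to compound 3 (0.37 log units; beyond the scatter), so the compound with the piperazine is removed faster. The change from compound 2 to compound 3 cannot be read, as compound 2 has no number. Nothing measured here explains the rise.

Going by these compounds, whether it comes from the six-membered ring, the second nitrogen or the methyl stays open. A morpholin-4-yl or an unsubstituted piperazin-1-yl group on the same carbonyl carbon would help separate these.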